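Hydrazone aryl swaps on the shared core

This account rests on a few compounds, and the source may have more. Where it says the series, first, only, none or still open, it means among the compounds named here.

Compound 1 `Cc1c(C(=O)N/N=C\c2cccc(F)c2O)oc2cccc(O)c12` gives 12700 nM in a functional assay on PC-3 cells (Homo sapiens) for inhibition (a higher number here means a weaker inhibitor, a lower number a stronger inhibitor), and stands as the highest of the two numbers on hand. Compound 2 `Cc1ccc(O)c(/C=N\NC(=O)c2oc3cccc(O)c3c2C)c1` gives 7350 nM in this assay, the step being a 1.7-fold lower number from compound 1 to compound 2 (0.24 log units; within the scatter). Compound 3 `Cc1c(C(=O)N/N=C\c2ccncc2)oc2cccc(O)c12` gives only a limit in this assay, >= 40000 nM. The steps of an at least 3.1-fold higher number from compound 1 to compound 3 (0.49 log units; beyond the scatter) and an at least 5.4-fold higher number from compound 2 to compound 3 (0.73 log units; beyond the scatter) are both read against that limit (the limit of >= 40000 nM in this assay, at which 1 of the 3 values shown sits). Compound 4 `Cc1c(C(=O)N/N=C\c2cc(Cl)ccc2O)oc2cccc(O)c12` carries 5-chloro-2-hydroxyphenyl in place of 3-fluoro-2-hydroxyphenyl on a carbon with a double bond to nitrogen. Among the measured compounds shown here, only the step from compound 1 to compound 2 bears on this change, since the 2-hydroxyphenyl is kept there too, and it lay within the scatter; a step of similar size, or none, is expected here. Compound 4 is therefore estimated at 8500 nM in this assay, within 3500 nM to 20000 nM, meaning an expected step of a 1.5-fold lower number from compound 1 to compound 4 (0.17 log units; within the scatter).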

Compound 4, half-maximal inhibitory concentration: 3120 nM
Estimate against measurement, compound 4: 2.7-fold (0.44 log units) above, outside the stated range (below it).
By their numbers in this assay, from the lowest: compound 4; then compounds 2 and 1 (each within the scatter of the next). At a limit, above all of these: compound 3.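

Among the compounds shown here, on the carbon with a double bond to nitrogen, 5-chloro-2-hydroxyphenyl gives the first step beyond the scatter among the 2-hydroxyphenyl compounds: a 4.1-fold lower number from compound 1 to compound 4 (0.61 log units; beyond the scatter). Chloro in place of methyl on an aromatic carbon also registers, at a 2.4-fold lower number from compound 2 to compound 4 (0.37 log units; beyond the scatter), so the substituent on the 2-hydroxyphenyl can shift the number in this assay. The step of an at least 12-fold lower number from compound 3 to compound 4 (1.10 log units; beyond the scatter) is the largest here, but the figure for compound 3 is a limit: the limit of >= 40000 nM in this assay, at which 1 of the 4 values shown sits.

Fluoro and chloro differ in both halogen and place, so which of the two drives the step stays open. From the compounds shown here alone, how bromo, methoxy or an amine would read in place of the chloro also stays open.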